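The source may report more compounds than this note shows. Statements on the series, on what has been measured and on what is new or still open speak of the compounds shown alone.

In a functional assay on HCT-116 cells (Homo sapiens) for cytotoxicity, read by sulforhodamine B assay, with a stated time of 48 h (on this read-out higher numbers stand for weaker inhibition and lower numbers for stronger inhibition), compound 1 (`COc1ccc(C(=O)Nc2n[nH]c3c2CN(C(=O)c2ccccc2)C3)cc1`) gives 13600 nM, compound 2 (`CCC(=O)n1nc(NC(=O)c2ccccc2)c2c1CN(C(=O)c1ccccc1)C2`) gives 1060 nM and compound 3 (`O=C(Nc1nn(C(=O)c2ccccc2)c2c1CN(C(=O)c1ccccc1)C2)c1ccccc1`) gives 1400 nM. Compound 3 thus stands within the scatter of compound 2, and its number is well below that of compound 1, a gap beyond the scatter.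

Compound 4 (`COc1ccc(C(=O)Nc2nn(C(=O)c3ccccc3)c3c2CN(C(=O)c2ccccc2)C3)cc1`) has not yet been measured. It differs from compound 3 by methoxy in place of hydrogen on an aromatic carbon. Among the compounds with values here, no measured step isolates this change. The only one available, a 1.3-fold higher number from compound 2 to compound 3 (0.12 log units; within the scatter), is a different change, phenyl in place of ethyl on a carbonyl carbon. Compound 1 carries the same methoxy group, but it also lacks a benzoyl group that compound 3 has, so the gap between them cannot be assigned to methoxy alone. No shift beyond the scatter is therefore expected in this assay. The estimated step is a 1.1-fold higher number from compound 3 to compound 4 (0.03 log units; within the scatter). The expected value for compound 4 is 1500 nM, with an estimated range of 600 nM to 4000 nM.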

Compound 4, half-maximal inhibitory concentration: 31300 nM
The estimate for compound 4 lay 21-fold (1.32 log units) below the measured number, outside the stated range (above it).
By their numbers in this assay, from the lowest: compounds 2 and 3 (each within the scatter of the next); then compound 1; then compound 4.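

In this assay, within the data shown here, methoxy on the aromatic carbon para to a large group is far from a silent change on this ring: a 22-fold higher number from compound 3 to compound 4 (1.35 log units; beyond the scatter), a large step that no earlier pair could isolate. With that methoxy present, benzoyl on the aromatic nitrogen also moves the number, a modest step: a 2.3-fold higher number from compound 1 to compound 4 (0.36 log units; beyond the scatter). Nothing measured here offers an explanation for either step.

The compounds shown leave open whether a hydroxy group, an amine or a fluorine atom on that same aromatic carbon would move the number as methoxy does. They also leave open whether the methoxy step would be of similar size with the propanoyl group of compound 2 on the aromatic nitrogen in place of benzoyl.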